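Chloro for Methyl in a Fibrosis Reporter Series

A few compounds are considered here, and "the series" means these few. Any claim that something is new, unique, unknown or untested is made for them only; others in the source may bear on it.

Measured compounds:
Compound 1, `Cc1ccc(-n2cc(C(=O)Nc3cc(F)cc(F)c3)c(=O)c3ccc(N(C)C)nc32)cc1OCCCCCCC[N+]1(C)CCCC1`, gives 12.7%.
Compound 2, `CN(C)c1ccc2c(=O)c(C(=O)Nc3cc(F)cc(F)c3)cn(-c3ccc(Cl)c(OCCCCCCC[N+]4(C)CCCC4)c3)c2n1`, gives 51%.
Compound 3, `CC[N+]1(CCCCCCCOc2cc(-n3cc(C(=O)Nc4cc(F)cc(F)c4)c(=O)c4ccc(N(C)C)nc43)ccc2C)CCCC1`, gives 57%.

All three were tested in an assay on LX2 cells for inhibition of COL1A1 promoter (Homo sapiens), read by a luciferase reporter, with a stated time of 24 h, tested at 20 uM; on this read-out lower numbers stand for a weaker effect and higher numbers for a stronger effect at the one concentration tested. Compound 1 stands lowest. Two single changes from it each raised the read-out by a large amount. One is chloro in place of methyl on an aromatic carbon, which gave a number 38.3 percentage points higher from compound 1 to compound 2 (beyond the scatter). The other is methyl in place of hydrogen on a saturated chain carbon bound to an amine nitrogen in a ring, which gave a number 44.3 percentage points higher from compound 1 to compound 3 (beyond the scatter). Compound 3 holds the highest number of the three, but its value and that of compound 2 lie within the usual scatter of each other, so no order between those two can be claimed.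

Compound 4, `CC[N+]1(CCCCCCCOc2cc(-n3cc(C(=O)Nc4cc(F)cc(F)c4)c(=O)c4ccc(N(C)C)nc43)ccc2Cl)CCCC1`, has not yet been measured. It differs from compound 3 by chloro in place of methyl on an aromatic carbon. This is the same change that was made from compound 1 to compound 2, at the same place, and that step was large. The core of compound 3, however, is not the core of compound 1: the two differ by methyl in place of hydrogen on a saturated chain carbon bound to an amine nitrogen in a ring, so the change is being made on a compound that already sits high in this assay.

For compound 4 the expected step is a number 15 percentage points higher from compound 3 to compound 4 (beyond the scatter), smaller than the earlier one because compound 3 already gives 57%. The estimate for compound 4 in this assay is 72%, with a likely range from 50% to 92%.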

Compound 4, a percentage reported as inhibition, at one concentration (the size of the read-out at that concentration, not a potency): 46%
Beside the measured number, compound 4's estimate is 26 percentage points above it; measured number below the stated range.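

Chloro in place of methyl on an aromatic carbon now gives a number 11 percentage points lower from compound 3 to compound 4 (beyond the scatter) in this assay, so this change does not carry from one core to the other with the same size or even the same direction: the same change on two cores in this assay, a number 38.3 percentage points higher (beyond the scatter) from compound 1 to compound 2 and a number 11 percentage points lower (beyond the scatter) from compound 3 to compound 4, 49.3 percentage points apart, beyond the scatter of two such steps

Methyl in place of hydrogen on a saturated chain carbon bound to an amine nitrogen in a ring depends on its partner in the same way, since it gives a number 5 percentage points lower from compound 2 to compound 4 (within the scatter), so the large gain it brought to the compound carrying methyl on the aromatic carbon does not appear in the compound carrying chloro there: the same change on two cores in this assay, a number 44.3 percentage points higher (beyond the scatter) from compound 1 to compound 3 and a number 5 percentage points lower (within the scatter) from compound 2 to compound 4, 49.3 percentage points apart, beyond the scatter of two such steps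

What this does not show is why the two changes depend on each other, or whether the same holds on any other core, as these four compounds form only one such set and each was read at a single concentration, which says nothing about potency.

From the compounds shown here alone, it remains open how other groups on that aromatic carbon, such as fluoro, bromo or methoxy, would behave on these two cores. Also open, going by these compounds, is whether a longer chain on the same ring nitrogen would follow compound 3 or compound 4.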